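This account rests on a few compounds, and the source may have more. Where it says the series, first, only, none or still open, it means among the compounds named here.

Three compounds of a shared core, each carrying a different aryl group on an amine nitrogen in a ring, have been tested in a functional assay on the whole organism (strain CD1) with Mus musculus as the target, in the maximal electroshock model, with a stated time of 0.5 h; a lower number here means that less compound is needed, a higher number that more compound is needed for the effect. Compound 1 `CCC1(C)CC(=O)N(CC(=O)N2CCN(c3ccccc3Cl)CC2)C1=O` gives 100 mg/kg. Compound 2 `Cc1cccc(N2CCN(C(=O)CN3C(=O)CC(C)C3=O)CC2)c1` gives 300 mg/kg. Compound 3 `CC1CC(=O)N(CC(=O)N2CCN(c3cccc(C(F)(F)F)c3)CC2)C1=O` gives 100 mg/kg. Of these three numbers, compound 2 has the highest, so the most compound is needed for its effect; its nearest neighbour is compound 1, and compound 3 sits at the same distance.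

Compound 4 `CC1CC(=O)N(CC(=O)N2CCN(c3ccccc3F)CC2)C1=O` has not yet been measured. It differs from compound 2 in one place: 2-fluorophenyl in place of 3-methylphenyl on an amine nitrogen in a ring.

Among the measured compounds shown here, only one measured step speaks to this change. Going from compound 2 to compound 3 puts trifluoromethyl in place of methyl on an aromatic carbon, and this gave a 3.0-fold lower number from compound 2 to compound 3 (0.48 log units; beyond the scatter). For the measured compounds named here, no step shows fluorine replacing methyl on the aryl group, and the pair of compound 1 and compound 2 differs in more than one place, so only their two values can be read. A halogen-bearing aryl in place of the methyl-bearing one, as in compound 3, is therefore expected to lower the number modestly, by about a 3.0-fold lower number from compound 2 to compound 4 (0.48 log units; beyond the scatter).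

For compound 4 the estimate is 100 mg/kg, with a range from 30 mg/kg to 300 mg/kg.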

Compound 4, minimum effective dose: 300 mg/kg
Compound 4: the middle estimate sits 3.0-fold (0.48 log units) below what was measured; the range from low to high includes it.
By their numbers in this assay, from the lowest: compounds 1 and 3 (each within the scatter of the next); then compounds 2 and 4 (each within the scatter of the next).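

In this assay, putting 2-fluorophenyl in place of 3-methylphenyl on the amine nitrogen in a ring gives no change at the digits printed from compound 2 to compound 4 (within the scatter), so this swap of one aryl group for another, with the same count of heavy atoms, leaves the number where it was. Among the compounds shown here, the only earlier step on this aryl group, trifluoromethyl in place of methyl on an aromatic carbon, gave a 3.0-fold lower number from compound 2 to compound 3 (0.48 log units; beyond the scatter), and the new result shows that such a lowering does not follow from every fluorine-bearing aryl group at this position. No measurement offered here accounts for the difference between these two steps.

The names 3-methylphenyl and 2-fluorophenyl differ both in the group on the phenyl ring and in the number that gives its place, so the compounds shown leave open which of these two differences matters, if either does. They also leave open how this position responds to an unsubstituted phenyl, or to a phenyl carrying a methoxy group or a nitrile, on the same shared core.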